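Chloro in place of fluoro on the furan-3-yl compound

A few compounds are considered here, and "the series" means these few. Any claim that something is new, unique, unknown or untested is made for them only; others in the source may bear on it.

In a functional assay on HCT-116 cells (Homo sapiens), read by sulforhodamine B assay, with a stated time of 5 days (on this read-out lower numbers stand for stronger inhibition of growth and higher numbers for weaker inhibition of growth), compound 1 (`OC[C@H]1O[C@@H](n2cc(F)c3c(-c4cccs4)ncnc32)[C@H](O)[C@@H]1O`) gives 9 nM, compound 2 (`OC[C@H]1O[C@@H](n2cc(F)c3c(-c4ccoc4)ncnc32)[C@H](O)[C@@H]1O`) gives 18 nM and compound 3 (`OC[C@H]1O[C@@H](n2cc(F)c3c(-c4cc[nH]c4)ncnc32)[C@H](O)[C@@H]1O`) gives 250 nM. Compound 2 sits with compound 1 at the low end of these numbers, with a 2.0-fold higher number from compound 1 to compound 2 (0.30 log units; within the scatter). The gap on the other side is large, with a 14-fold higher number from compound 2 to compound 3 (1.14 log units; beyond the scatter).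

Compound 4 (`OC[C@H]1O[C@@H](n2cc(Cl)c3c(-c4ccoc4)ncnc32)[C@H](O)[C@@H]1O`) keeps the furan-3-yl group of compound 2 and carries chloro in place of fluoro on an aromatic carbon. In words, this is chloro in place of fluoro on an aromatic carbon of a five-membered aromatic ring with 1 nitrogen.

Among the compounds with values here, none of the measured steps changes this halogen. All three exchange the aromatic group while fluoro stays in place, so they bear on the new step only indirectly. They show that one exchange in this series can stay within the scatter, as in a 2.0-fold higher number from compound 1 to compound 2 (0.30 log units; within the scatter), or go well beyond it, as in a 28-fold higher number from compound 1 to compound 3 (1.44 log units; beyond the scatter). Within the data shown here, both large steps involve compound 3, and no measured step shows what a halogen exchange does here, so the range is kept wide.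

The expected change in this assay is a 1.2-fold higher number from compound 2 to compound 4 (0.09 log units; within the scatter), which is no shift beyond the scatter. For compound 4 the estimate is 22 nM, with an expected range of 7 nM to 70 nM.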

Compound 4, concentration for 50% growth inhibition: 2000 nM
Estimate against measurement, compound 4: 91-fold (1.96 log units) below; measured number outside the range, above it.
By their numbers in this assay, from the lowest: compounds 1 and 2 (each within the scatter of the next); then compound 3; then compound 4.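

In this assay this place on the five-membered aromatic ring proves highly sensitive: chloro in place of fluoro gives a 110-fold higher number from compound 2 to compound 4 (2.05 log units; beyond the scatter) on the furan-3-yl compound, although one halogen atom simply replaces another and the counts of hydrogen-bond donors and acceptors and the net charge stay unchanged. The earlier steps shown here all held fluoro fixed and varied only the aromatic group, with a 28-fold higher number from compound 1 to compound 3 (1.44 log units; beyond the scatter) as the largest of them, so this single pair shows that for the furan-3-yl compound the halogen can matter at least as much as the aromatic group. Nothing available explains the size of this step.

The compounds shown leave open whether chloro brings a comparable loss alongside the thiophen-2-yl group of compound 1 or the 1H-pyrrol-3-yl group of compound 3. They also leave open how far the response at this carbon depends on the group placed there, as hydrogen, bromo, methyl, nitrile or an amine in place of fluoro would show.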